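Trifluoromethoxy to Trifluoroethoxy: Compound 4 Before Measurement

This account rests on a few compounds, and the source may have more. Where it says the series, first, only, none or still open, it means among the compounds named here.

compound 1 `COc1ccccc1N1CCN(CCCNc2ncccc2C(=O)N(C)C)CC1` — 20 nM
compound 2 `CN(C)C(=O)c1cccnc1NCCCN1CCN(c2ccccc2)CC1` — 15.9 nM
compound 3 `CN(C)C(=O)c1cccnc1NCCCN1CCN(c2ccccc2OC(F)(F)F)CC1` — 100 nM

In a functional assay on aorta for antagonist activity at Alpha-1D adrenergic receptor (Rattus norvegicus) (a lower number here means tighter binding, a higher number weaker binding), compound 3 stands highest of the three numbers; the nearer gap is a 5.0-fold higher number from compound 1 to compound 3 (0.70 log units; beyond the scatter) and the wider one a 6.3-fold higher number from compound 2 to compound 3 (0.80 log units; beyond the scatter), both modest and both beyond the scatter. Compound 4 `CN(C)C(=O)c1cccnc1NCCCN1CCN(c2ccccc2OCC(F)(F)F)CC1` carries the change (2,2,2-trifluoroethyl in place of trifluoromethyl on an oxygen on an aromatic ring). Going by the values given here, the two steps that bear on it are those that built the trifluoromethoxy group, namely a 5.0-fold higher number from compound 1 to compound 3 (0.70 log units; beyond the scatter) and a 6.3-fold higher number from compound 2 to compound 3 (0.80 log units; beyond the scatter); no measured step tests a longer group on that oxygen. The entering group keeps the three fluorines and adds one carbon, so the expectation is a number between those of compound 3 and compound 1, a modest fall that could still sit within the scatter. Compound 4 is therefore estimated at 50 nM, ranging from 15 nM to 160 nM, which would be an expected step of a 2.0-fold lower number from compound 3 to compound 4 (0.30 log units; within the scatter).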

Compound 4, dissociation constant: 15.9 nM
Compound 4: middle estimate off by 3.1-fold (0.50 log units), on the high side; the range from low to high includes it.
By their numbers in this assay, from the lowest: compounds 2, 4 and 1 (each within the scatter of the next); then compound 3.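

In this assay, the extra carbon on that oxygen reverses the loss seen with trifluoromethoxy (a 6.3-fold lower number from compound 3 to compound 4 (0.80 log units; beyond the scatter)), so three fluorines in the group do not by themselves bring the higher number. The 2,2,2-trifluoroethoxy group is accepted at this place, with both remaining steps within the scatter (no change at the digits printed from compound 2 to compound 4 (within the scatter); a 1.3-fold lower number from compound 1 to compound 4 (0.10 log units; within the scatter)). Nothing available here explains the difference between the trifluoromethyl and 2,2,2-trifluoroethyl groups. The compounds shown leave open whether the fluorines matter on this chain, which an ethyl group on that oxygen would test, and whether a longer chain such as 3,3,3-trifluoropropyl would behave the same way.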